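Halogen swap on the benzyl arm of two cores

The source may hold more compounds than are shown below. What is called first, only, known or untested is meant among the compounds shown, and "the series" means these compounds.

Measured so far in a functional assay on PC-3 cells (Homo sapiens) for cytotoxicity, read by MTT assay, with a stated time of 24 h; on this read-out higher numbers stand for weaker inhibition and lower numbers for stronger inhibition:
compound 1 `O=C1/C(=C/c2ccccc2F)CN(Cc2cn(Cc3ccccc3F)nn2)C/C1=C\c1ccccc1F` gives 19700 nM
compound 3 `O=C1/C(=C/c2ccccc2F)CN(Cc2cn(Cc3ccccc3Cl)nn2)C/C1=C\c1ccccc1F` gives 7100 nM
compound 2 `Cc1ccc(/C=C2\CN(C(=S)SCc3cn(Cc4ccccc4F)nn3)C/C(=C\c3ccc(C)cc3)C2=O)cc1` reaches only the limit > 80000 nM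

Compound 2 and compound 1 share no counted single-point difference; the difference between the two cores is not broken down here. Within the core of compound 1, the change from compound 1 to compound 3 is chloro in place of fluoro on an aromatic carbon; in this assay it makes a 2.8-fold lower number from compound 1 to compound 3 (0.44 log units; beyond the scatter). Compound 4 `Cc1ccc(/C=C2\CN(C(=S)SCc3cn(Cc4ccccc4Cl)nn3)C/C(=C\c3ccc(C)cc3)C2=O)cc1`, not yet measured, carries the same change set on the core of compound 2: chloro in place of fluoro on an aromatic carbon. The two places read the same word for word, so this is the same change on a different core.

For compound 2 only a limit is known in this assay; the limit of > 80000 nM in this assay, at which 1 of the 3 values shown sits, is where its value sits. A step of the size seen from compound 1 to compound 3, started from a value that is itself a limit, need not bring compound 4 inside the measurable range of this assay. Compound 4 is expected to show an at least 1.3-fold lower number from compound 2 to compound 4 (0.12 log units; that floor lies within the scatter) in this assay, and that expectation rests on the step of a 2.8-fold lower number from compound 1 to compound 3 (0.44 log units; beyond the scatter) of the measured pair. The estimate for compound 4 is 60000 nM, with a range from 25000 nM to 120000 nM, and a fair chance that this assay again reports only a limit.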

Compound 4, half-maximal inhibitory concentration: > 80000 nM
Compound 4 was reported as a limit; the forecaster's own chance of this, stated with the estimate: 55%; middle value at least 1.3-fold (0.12 log units) away from the limit.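

In this assay, compound 2 and compound 4 are both reported only as limits, so no step from 2-fluorobenzyl to 2-chlorobenzyl can be read between them: the limit of > 80000 nM in this assay, at which 2 of the 4 values shown sit.

The compounds shown leave open whether chloro in place of fluoro changes the value at all on the core of compound 2, as it does between compound 1 and compound 3 on their core.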